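The source may report more compounds than this note shows. Statements on the series, on what has been measured and on what is new or still open speak of the compounds shown alone.

Compound 2, `C=C[C@@H]1C[C@]1(NC(=O)[C@@H]1C[C@@H](Oc2nccc3cc(OC)ccc23)CN1C(=O)[C@@H](NC(=O)N[C@H](COC)C(C)C)C(C)(C)C)C(=O)NS(=O)(=O)C1CC1`, carries a 1-(methoxymethyl)-2-methylpropyl group on a urea nitrogen of a shared core that also bears a cyclopropyl acylsulfonamide. Among the measured compounds shown here, in a physicochemical assay for solubility, in phosphate buffer, at pH 6.5 (a lower number here means a less soluble compound, a higher number a more soluble compound), compound 2 gives 570 ug/mL, the lowest of the three numbers known so far, though compound 1, `C=C[C@@H]1C[C@]1(NC(=O)[C@@H]1C[C@@H](Oc2nccc3cc(OC)ccc23)CN1C(=O)[C@@H](NC(=O)N[C@@H](C)COC)C(C)(C)C)C(=O)NS(=O)(=O)C1CC1`, with 1070 ug/mL, and compound 3, `C=C[C@@H]1C[C@]1(NC(=O)[C@@H]1C[C@@H](Oc2nccc3cc(OC)ccc23)CN1C(=O)[C@@H](NC(=O)N[C@H](C(=O)OC)C(C)(C)C)C(C)(C)C)C(=O)NS(=O)(=O)C1CC1`, with 754 ug/mL, both sit within the scatter of it: a 1.9-fold lower number from compound 1 to compound 2 (0.27 log units; within the scatter) and a 1.3-fold higher number from compound 2 to compound 3 (0.12 log units; within the scatter) are each small, as is a 1.4-fold lower number from compound 1 to compound 3 (0.15 log units; within the scatter).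

Compound 4, `C=C[C@@H]1C[C@]1(NC(=O)[C@@H]1C[C@@H](Oc2nccc3cc(OC)ccc23)CN1C(=O)[C@@H](NC(=O)N[C@H](C(=O)OC(C)(C)C)C(C)(C)C)C(C)(C)C)C(=O)NS(=O)(=O)C1CC1`, differs from compound 2 in one place: 2,2-dimethyl-1-(tert-butoxycarbonyl)propyl in place of 1-(methoxymethyl)-2-methylpropyl on an amide-type nitrogen. For the measured compounds named here, the steps that bear on this are the exchange of side chains on the same urea nitrogen, a 1.3-fold higher number from compound 2 to compound 3 (0.12 log units; within the scatter), which swapped in a methyl ester, and a 1.9-fold lower number from compound 1 to compound 2 (0.27 log units; within the scatter); neither rose above the scatter. The further change to a tert-butyl ester has no measured parallel here, so only a small step can be inferred. In this assay compound 4 is therefore expected to give about 350 ug/mL, a step of a 1.6-fold lower number from compound 2 to compound 4 (0.21 log units; within the scatter), with a likely range from 150 ug/mL to 800 ug/mL.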

Compound 4, solubility: 1 ug/mL
The estimate for compound 4 lay 350-fold (2.54 log units) above the measured number; the whole stated range lies above it.
By their numbers in this assay, from the lowest: compound 4; then compounds 2, 3 and 1 (each within the scatter of the next).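

The side chains of compounds 1, 2 and 3 on this amide-type nitrogen had all stayed within the scatter of one another in this assay, and compound 4 shows that the position does not accept every exchange. The cleanest reading is a 750-fold lower number from compound 3 to compound 4 (2.88 log units; beyond the scatter) with only tert-butyl in place of methyl on an oxygen next to a carbonyl group, so the fall belongs to the change of ester alkyl group and not to the presence of an ester, which compound 3 also carries. The wider exchanges give steps of similar size: a 570-fold lower number from compound 2 to compound 4 (2.76 log units; beyond the scatter) and a 1100-fold lower number from compound 1 to compound 4 (3.03 log units; beyond the scatter) both lie far beyond the scatter.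

Nothing available here explains these steps. Going by these compounds, whether an ethyl or isopropyl ester, or a carboxylic acid in place of the ester, would stay with compound 3 or fall with compound 4 remains open.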